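A few compounds are considered here, and "the series" means these few. Any claim that something is new, unique, unknown or untested is made for them only; others in the source may bear on it.

Measured so far:
- compound 1, `O=C(Nc1ncc(Cc2ccc(F)cc2)s1)C1CCCCC1`: > 50000 nM
- compound 2, `O=C(Nc1ncc(C(Oc2ccc3cc(Br)ccc3c2)c2ccc(Cl)cc2)s1)c1cccs1`: "not toxic" (no number reported)
- compound 3, `COc1ccc(COC(c2ccccc2)c2cnc(NC(=O)c3cccs3)s2)cc1`: "not toxic" (no number reported)

Compound 1 `O=C(Nc1ncc(Cc2ccc(F)cc2)s1)C1CCCCC1` in an ADME assay on HepG2 2.2.15 cells (Homo sapiens) for cytotoxicity (a lower number here means that less compound is tolerated, a higher number that more compound is tolerated), gives > 50000 nM, which is a limit of the assay and not a number. Compound 2 `O=C(Nc1ncc(C(Oc2ccc3cc(Br)ccc3c2)c2ccc(Cl)cc2)s1)c1cccs1` gives "not toxic" (no number reported) in this assay, again without a number. Compound 3 `COc1ccc(COC(c2ccccc2)c2cnc(NC(=O)c3cccs3)s2)cc1` gives "not toxic" (no number reported). So compound 2 stands among entries that show no single number; the only thing to hold on to is the limit of > 50000 nM in this assay, at which 1 of the 3 values shown sits.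

Compound 4 `COCCCNc1ncc(C(Oc2ccc3cc(Br)ccc3c2)c2ccc(Cl)cc2)s1` is not yet measured. It differs from compound 2 by 3-methoxypropyl in place of (thiophen-2-yl)carbonyl on a nitrogen on an aromatic ring. Within the data shown here, no measured step exists for such a change in this assay; no shift beyond the scatter is expected, and a limit again is the likelier outcome. Compound 4 is expected near 50000 nM, within 20000 nM to 100000 nM.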

Compound 4, half-maximal cytotoxic concentration: "not toxic" (no number reported)
Nothing numeric was reported for compound 4, and the estimate cannot be compared.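

Compound 2 and compound 4 are both reported as not toxic, without a number, so no step can be read between them. From the compounds shown here alone, whether 3-methoxypropyl in place of (thiophen-2-yl)carbonyl shifts the tolerated concentration stays open.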